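This account rests on a few compounds, and the source may have more. Where it says the series, first, only, none or still open, it means among the compounds named here.

Compound 1 `CCN(CC)CCCC(C)/N=C(/N)NC(=O)c1cccc(Cl)c1CCc1cc(Br)ccc1OC` gives 0.83 nM in an assay for binding affinity to Melanocortin receptor 4 (Homo sapiens); on this read-out lower numbers stand for stronger inhibition and higher numbers for weaker inhibition.
Compound 2 `COc1ccc(Br)cc1CCc1c(F)cccc1C(=O)/N=C(\N)NCCN1CCCC1` gives 190 nM in this assay.
Compound 3 `CCN(CC)CCCC(C)/N=C(/N)NC(=O)c1cccc(F)c1CCc1ccc2ccccc2c1` gives 690 nM in this assay.

Among these three measured compounds, compound 2 holds the second highest number. Its value lies nearer to that of compound 3, whose number is higher still, and far from that of compound 1, whose number is much lower; both of these gaps are larger than the usual scatter of the measurement.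

Compound 4 `COc1ccc(Br)cc1CCc1c(F)cccc1C(=O)/N=C(\N)NCCCN1CCCCC1` has not yet been measured. It differs from compound 2 in one place: (piperidin-1-yl)methyl in place of pyrrolidin-1-yl on a saturated chain carbon, two bonds along the chain from an amine nitrogen. In words, the amine end of the side chain grows from a five-membered ring on a shorter chain to a six-membered ring on a longer chain, while the rest of the molecule stays the same.

Among the measured compounds shown here, no pair of measured compounds differs in exactly this way, so no measured step shows what this change does. Compound 1, the strongest binder shown, carries a longer amine-bearing chain than compound 2, but it also differs elsewhere, so it cannot serve as a direct guide. The expectation is therefore a modest step toward stronger binding for compound 4, of a size that may only just exceed the scatter, with a wide range of uncertainty: compound 4 is estimated at 80 nM, between 15 nM and 400 nM. The expected step is a 2.4-fold lower number from compound 2 to compound 4 (0.38 log units; beyond the scatter).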

Compound 4, inhibition constant: 3.2 nM
For compound 4 the middle estimate is 25-fold (1.40 log units) above the measured one; measured number outside the range, below it.
By their numbers in this assay, from the lowest: compound 1; then compound 4; then compound 2; then compound 3.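

In this assay, the amine end of the side chain proves to be a powerful handle on binding: (piperidin-1-yl)methyl in place of pyrrolidin-1-yl, on a saturated chain carbon two bonds along the chain from an amine nitrogen, gives a 59-fold lower number from compound 2 to compound 4 (1.77 log units; beyond the scatter), a large step well beyond the scatter. This is the first direct reading of a single change among these compounds, and it shows that this end of the molecule alone can move the number a long way while everything else stays the same. Nothing available explains why the step is so large.

The change alters the ring and the chain together, so the compounds shown leave open how much of the step belongs to the six-membered ring and how much to the longer chain; 2-(piperidin-1-yl)ethyl and 3-(pyrrolidin-1-yl)propyl would separate the two. Also open, as far as these compounds go, is how far the trend extends, for instance to a 4-(piperidin-1-yl)butyl chain or to a morpholine ring at the chain end.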